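Ethyl for phenyl when only limits are known

The compounds below may be only part of what the source reports. "The series", "measured", "known", "first", "only" and "open" are said of these compounds alone.

In an ADME assay on BaF3 cells (Mus musculus) for cytotoxicity, read by MTT assay, with a stated time of 48 h (a higher number here means a weaker inhibitor of growth, a lower number a stronger inhibitor of growth), compound 3 (`CC(C)n1nc(-c2cc(-c3ccccc3)on2)c2c(N)ncnc21`) gives > 10000 nM as a limit, not a number. Compound 1 (`CC(C)n1nc(-c2cc(C3CCCCC3)on2)c2c(N)ncnc21`) gives > 10000 nM as a limit too. Compound 2 (`CC(C)n1nc(-c2cc(C(C)(C)C)on2)c2c(N)ncnc21`) gives > 10000 nM as a limit as well.

Compound 4 (`CCc1cc(-c2nn(C(C)C)c3ncnc(N)c23)no1`) differs from compound 3 in one place, with ethyl in place of phenyl on an aromatic carbon. Among the measured compounds shown here, three measured steps bear on this change, and none has a readable size: one is a step that the two limits leave unreadable from compound 1 to compound 2 and another is a step that the two limits leave unreadable from compound 1 to compound 3 while the third is a step that the two limits leave unreadable from compound 2 to compound 3 in the same place.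

Resting on the limit of > 10000 nM in this assay, at which 3 of the 3 values shown sit, for these compounds, no step beyond the scatter is expected in this assay and no direction can be given. The estimated change is a number no higher from compound 3 to compound 4 (the limit leaves the size open) with the result likely to be reported as a limit. For compound 4 the estimate is 10000 nM with an expected range (4000 nM to 20000 nM).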

Compound 4, concentration for 50% growth inhibition: > 10000 nM
Compound 4: only a limit was reported (the forecaster's own chance of this, stated with the estimate: 85%); the middle value sits exactly at the limit.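

In this assay compound 4 gives > 10000 nM, which is a limit and not a number. The steps linking compound 4 with compound 1, compound 2 and compound 3 cannot be read. The compounds shown leave open whether changing this group alters growth inhibition at all, because all of them share one limit: the limit of > 10000 nM in this assay, at which 4 of the 4 values shown sit.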